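This account rests on a few compounds, and the source may have more. Where it says the series, first, only, none or still open, it means among the compounds named here.

Compound 1 `Cc1ccccc1-c1n[nH]c(-c2ccccc2)n1` and compound 2 `Cc1ccc(C)c(-c2n[nH]c(-c3ccccc3)n2)c1` share the same core and differ only in the groups on one ring. In a functional assay on the whole organism (Cricetulus griseus) with Cricetinae gen. sp. as the target (a higher number here means that more compound is needed for the effect, a lower number that less compound is needed), compound 1 gives 0.3 mg/kg; 0.3 mg/kg (2 entries). In this assay compound 2 reaches only a limit of the assay, > 10 mg/kg, so no single number is known for it; it sits at the limit of > 10 mg/kg in this assay, at which 1 of the 2 values shown sits, and a further entry also gave no number. Compound 3 `COc1ccc(C)c(-c2n[nH]c(-c3ccccc3)n2)c1` follows from compound 2 by methoxy in place of methyl on an aromatic carbon. For the measured compounds named here, no measured step of this kind is available, so the change is expected to move the reading by no more than the usual scatter, with an expected step of a number no higher from compound 2 to compound 3 (the limit leaves the size open). Compound 3 is therefore estimated at 10 mg/kg, within 3 mg/kg to 30 mg/kg.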

Compound 3, dose for half-maximal effect: > 10 mg/kg
Compound 3 ended at the assay's limit; the forecaster's own chance of this, stated with the estimate: 60%; the middle value lies on the limit itself.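

For the compounds shown here, compound 2 and compound 3 both end at a limit in this assay, so no step between them can be read: the limit of > 10 mg/kg in this assay, at which 2 of the 3 values shown sit. The compounds shown leave open whether methoxy in place of methyl changes the dose needed at all.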